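A few compounds are considered here, and "the series" means these few. Any claim that something is new, unique, unknown or untested is made for them only; others in the source may bear on it.

Compound 1 `O=C(NNC(=O)c1ccc(-n2cccc2)cc1)c1ccccc1` was examined in an ADME assay on A549 cells (Homo sapiens) for cytotoxicity, read by MTT assay, with a stated time of 72 h (on this read-out higher numbers stand for weaker inhibition and lower numbers for stronger inhibition), where compound 1 gives 215000 nM. For the measured compounds named here, only one other compound has been measured there: compound 2 `O=C(NNC(=O)c1ccccc1[N+](=O)[O-])c1ccc(-n2cccc2)cc1` gives 205000 nM in this assay, and the step of a 1.0-fold lower number from compound 1 to compound 2 (0.02 log units; within the scatter) lies within the scatter. Compound 3 `O=C(NNC(=O)c1ccc([N+](=O)[O-])cc1)c1ccc(-n2cccc2)cc1` differs from compound 1 by nitro in place of hydrogen on an aromatic carbon. Going by the values given here, the single step of this same kind, a 1.0-fold lower number from compound 1 to compound 2 (0.02 log units; within the scatter), showed no movement beyond the scatter, so no step beyond the scatter in this assay is expected either way. For compound 3 the expected value is therefore 210000 nM, with a range of 100000 nM to 430000 nM, which means an expected step of a 1.0-fold lower number from compound 1 to compound 3 (0.01 log units; within the scatter).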

Compound 3, half-maximal inhibitory concentration: 198000 nM
The estimate for compound 3 lay 1.1-fold (0.03 log units) above the measured number; the range from low to high includes it.
By their numbers in this assay, from the lowest: compounds 3, 2 and 1 (each within the scatter of the next).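

With the nitro para to a large group, the change again leaves the number within the scatter in this assay (a 1.1-fold lower number from compound 1 to compound 3 (0.04 log units; within the scatter)). Compound 2 carries its nitro at another place on the same ring, so across the compounds shown, moving the nitro on this ring brings no step from compound 1 beyond the scatter. No measured evidence bears on this result. From the compounds shown here alone, whether an amine or a carboxylic acid at this place would move the number beyond the scatter stays open.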